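Methoxyphenyl for Fluorophenyl on the Hydrazide Carbonyl

The source may hold more compounds than are shown below. What is called first, only, known or untested is meant among the compounds shown, and "the series" means these compounds.

Measured compounds:
compound 1 `CC(/C=N/Nc1ccc([N+](=O)[O-])cc1)=N\NC(=O)c1ccccc1Nc1ccccc1`: "not determined" (no result reported)
compound 2 `CC(/C=N/Nc1ccc([N+](=O)[O-])cc1)=N\NC(=O)c1ccccc1F`: > 12000 nM
compound 3 `CC(/C=N/N(C)c1ccc([N+](=O)[O-])cc1)=N\NC(=O)c1cc([N+](=O)[O-])cc([N+](=O)[O-])c1`: 1110 nM

Three compounds share a core built around a hydrazone linker and a nitrophenyl hydrazine, and differ in the aryl attached to the carbonyl. In a functional assay on cells (Splenocyte, Mus musculus, strain BALB/c) for inhibition, read by scintillation counting and thymidine incorporation, with a stated time of 72 h (a lower number here means a stronger inhibitor, a higher number a weaker inhibitor), compound 2 reaches only a limit, reported as > 12000 nM, and no single number is attached to it. Compound 3 gives 1110 nM in this assay. For compound 1 this assay has no result. Compound 2 therefore sits at the weak end of what is shown, at the limit of > 12000 nM in this assay, at which 1 of the 3 values shown sits.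

Compound 4 `COc1ccc(C(=O)N/N=C(C)/C=N/Nc2ccc([N+](=O)[O-])cc2)cc1` differs from compound 2 by 4-methoxyphenyl in place of 2-fluorophenyl on a carbonyl carbon. Within the data shown here, no pair of measured compounds isolates this exchange, so the size of its effect cannot be read from the data. Compound 2 already stands at a limit, and compound 4 is expected to remain in the same weak region, with no change beyond the scatter that could be resolved. The estimate for compound 4 in this assay is 15000 nM, with a range from 3000 nM to 60000 nM. This estimate implies a step that the limit leaves unreadable from compound 2 to compound 4, expected to be essentially none.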

Compound 4, half-maximal inhibitory concentration: > 12000 nM
Compound 4 ended at the assay's limit; the forecaster's own chance of this, stated with the estimate: 65%; the middle value does not contradict the limit.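

Compound 2 and compound 4 both end at a limit of the assay, so no step between them can be read: the limit of > 12000 nM in this assay, at which 2 of the 4 values shown sit.

The compounds shown leave open how far 4-methoxyphenyl and 2-fluorophenyl on this carbonyl carbon differ in this assay.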